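The compounds below may be only part of what the source reports. "The series", "measured", "known", "first", "only" and "open" are said of these compounds alone.

Three compounds of the series, compound 1 `CCCCCCCCCCn1cc(/C=[N+](\[O-])c2ccccc2)nn1`, compound 2 `CCCCCCCCn1cc(/C=[N+](\[O-])Cc2ccccc2)nn1` and compound 3 `[O-]/[N+](=C\c1cn(CCC(F)(F)C(F)(F)C(F)(F)C(F)(F)C(F)(F)C(F)(F)F)nn1)Cc1ccccc1`, have been run in a functional assay on PC-3 cells (Homo sapiens) for inhibition, read by MTT assay, with a stated time of 24 h; on this read-out lower numbers stand for stronger inhibition and higher numbers for weaker inhibition. In this assay compound 1 gives only a limit, > 100000 nM. Compound 2 likewise returns a limit, > 100000 nM. Compound 3 also sits at a limit, > 100000 nM, so its standing on the numbers shown is simply (the limit of > 100000 nM in this assay, at which 3 of the 3 values shown sit), and no measured step separates any pair of these compounds. Compound 4 `[O-]/[N+](=C\c1cn(CCC(F)(F)C(F)(F)C(F)(F)C(F)(F)C(F)(F)C(F)(F)C(F)(F)C(F)(F)F)nn1)Cc1ccccc1` is not yet measured; it differs from compound 3 by 1,1,2,2,2-pentafluoroethyl in place of fluoro on a saturated chain carbon bound to two fluorine atoms and a saturated chain carbon. With every value shown resting at the limit, the expected step in this assay is a step that the limit leaves unreadable from compound 3 to compound 4, none beyond the scatter. For compound 4 the estimate in this assay is 150000 nM, within 50000 nM to 500000 nM, most likely again reported as a limit.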

Compound 4, half-maximal inhibitory concentration: 8100 nM
For compound 4 the middle estimate is 19-fold (1.27 log units) above the measured one; the measured number lies below the stated range.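

In this assay, fluoro giving way to 1,1,2,2,2-pentafluoroethyl on a saturated chain carbon bound to two fluorine atoms and a saturated chain carbon brings an at least 12-fold lower number from compound 3 to compound 4 (1.09 log units; beyond the scatter), so a change at this chain end can move the series off its limit. Steps among the other compounds cannot be read, and compound 4 alone carries a readable number: the limit of > 100000 nM in this assay, at which 3 of the 4 values shown sit. With a single readable value, no trend along the chain can be stated. From the compounds shown here alone, whether a longer fluorinated chain lowers the number further remains open, as does the effect of an amine or a carboxylic acid at the chain end.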